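The source may report more compounds than this note shows. Statements on the series, on what has been measured and on what is new or still open speak of the compounds shown alone.

Measured compounds:
Compound 1 `CN(C(=O)NC(=O)c1ccc(F)c(F)c1)c1nc(C(F)(F)F)c(C(=O)N/N=C/c2ccccc2C(F)(F)F)s1`: 10.4 ug/mL
Compound 2 `CN(C(=O)NC(=O)c1c(Cl)cccc1Cl)c1nc(C(F)(F)F)c(C(=O)N/N=C/c2ccccc2C(F)(F)F)s1`: 8.95 ug/mL

Both compounds were tested in a functional assay on HepG2 cells (Homo sapiens) for inhibition, read by MTT assay, with a stated time of 72 h; on this read-out higher numbers stand for weaker inhibition and lower numbers for stronger inhibition. In this assay compound 1 gives 10.4 ug/mL and compound 2 gives 8.95 ug/mL. Going by the values given here, the one measured step, a 1.2-fold lower number from compound 1 to compound 2 (0.07 log units; within the scatter), is too small to count as a real change, so compound 2 and compound 1 cannot be told apart on these numbers; compound 2 is simply one of two compounds sitting at about the same level.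

Compound 3 `CN(C(=O)NC(=O)c1ccccc1F)c1nc(C(F)(F)F)c(C(=O)N/N=C/c2ccccc2C(F)(F)F)s1` has not yet been measured. Relative to compound 2 the change is 2-fluorophenyl in place of 2,6-dichlorophenyl on a carbonyl carbon; the rest of the molecule stays the same. Among the compounds with values here, the only measured step that touches this position is a 1.2-fold lower number from compound 1 to compound 2 (0.07 log units; within the scatter), where exchanging one aryl group for another on the same carbonyl carbon left the number within the scatter. Compound 3 carries a third aryl group at that position, so the expectation is again a step of no real size, a 1.1-fold higher number from compound 2 to compound 3 (0.05 log units; within the scatter), in this assay. Compound 3 is therefore estimated to give about 10 ug/mL, with a likely range from 4.5 ug/mL to 22 ug/mL.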

Compound 3, half-maximal inhibitory concentration: 5.39 ug/mL
For compound 3 the middle estimate is 1.9-fold (0.27 log units) above the measured one, within the range that was stated.
By their numbers in this assay, from the lowest: compounds 3, 2 and 1 (each within the scatter of the next).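

In this assay, a 1.7-fold lower number from compound 2 to compound 3 (0.22 log units; within the scatter) and a 1.9-fold lower number from compound 1 to compound 3 (0.29 log units; within the scatter) are both small enough to count as no real change, so a third aryl group on this carbonyl carbon joins the other two at one level. The earlier pair compared only 3,4-difluorophenyl with 2,6-dichlorophenyl, whereas 2-fluorophenyl now shows that compounds 1, 2 and 3 cannot be told apart across these three halogen-bearing phenyl groups, even with fluorine in place of chlorine and 7 heavy atoms in place of 8 in the step from compound 2 to compound 3. No outside measurement is available to say why these numbers sit together.

Every group shown at this position is a phenyl ring carrying fluorine or chlorine, so it remains open whether an unsubstituted phenyl, a methoxyphenyl, a ring bearing an amine or a longer alkyl chain would stay at this level. The rest of the molecule is identical in all three compounds, which leaves open whether this read-out would respond more strongly to a change elsewhere.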